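Ester-to-amide swap on a long thioether chain

A few compounds are considered here, and "the series" means these few. Any claim that something is new, unique, unknown or untested is made for them only; others in the source may bear on it.

Compound 1 `Cn1c(Cc2nn(C)c(=O)c3ccccc23)nnc1SCCCCCCCCCCC(=O)Nc1ccc(Cl)cc1`: 20000 nM
Compound 2 `Cn1c(Cc2nn(C)c(=O)c3ccccc23)nnc1SCCCCCCCCCCC(=O)Oc1ccc(Cl)cc1Cl`: 8700 nM

Among the measured compounds shown here, in an assay on isolated protein (Mus musculus) for inhibition of IL15-IL15 receptor (Homo sapiens), read by resazurin assay, with stated times of 30 min and 2.5 days (a higher number here means a weaker inhibitor, a lower number a stronger inhibitor), compound 2 stands lowest of the two numbers, with compound 1 its only neighbour. Compound 3 `Cn1c(Cc2nn(C)c(=O)c3ccccc23)nnc1SCCCCCCCCCC(=O)Nc1ccc(Cl)cc1Cl` differs from compound 2 by (2,4-dichlorophenyl)carbamoyl in place of ((2,4-dichlorophenoxy)carbonyl)methyl on a saturated chain carbon, nine bonds along the chain from a sulfur. For the measured compounds named here, the single measured step, a 2.3-fold lower number from compound 1 to compound 2 (0.36 log units; beyond the scatter), went the opposite way, from an anilide to an aryl ester, and was modest. Returning to a carbamoyl group while keeping both chlorines is therefore expected to give, for compound 3, a step of a 1.4-fold higher number from compound 2 to compound 3 (0.14 log units; within the scatter) that stays close to the scatter. Compound 3 is estimated at 12000 nM, within 4000 nM to 35000 nM.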

Compound 3, half-maximal inhibitory concentration: 2300 nM
Estimate against measurement, compound 3: 5.2-fold (0.72 log units) above; measured number below the stated range.
By their numbers in this assay, from the lowest: compound 3; then compound 2; then compound 1.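

There is a 3.8-fold lower number from compound 2 to compound 3 (0.58 log units; beyond the scatter) and an 8.7-fold lower number from compound 1 to compound 3 (0.94 log units; beyond the scatter) in this assay so the anilide carrying both chlorines, not the aryl ester, holds the lowest number. Compound 1 and compound 2 alone did not show that a carbamoyl link at this place could go with a lower number than the ester. Nothing at hand explains this result. Each step changes more than one feature of the group, so the second chlorine and the lost methyl carbon cannot be told apart. On these data alone, how a carboxylic acid or an amine at this chain end, or the same anilide on a longer chain, would read remains open.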